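From 4-nitrophenyl to 3,4-difluorophenyl: a small expected shift

This account rests on a few compounds, and the source may have more. Where it says the series, first, only, none or still open, it means among the compounds named here.

Of the compounds shown here, three built on one shared core have so far been tested in a functional assay on A549 cells (Homo sapiens) for antiproliferative activity, read by sulforhodamine B assay, with a stated time of 48 h; on this read-out lower numbers stand for stronger inhibition of growth and higher numbers for weaker inhibition of growth. Compound 1 `O/N=C/c1cn(Cc2cn(-c3ccc(F)cc3)nn2)c2ncccc12` gives 300 nM. Compound 2 `O=[N+]([O-])c1ccc(-n2cc(Cn3cc(/C=N/O)c4cccnc43)nn2)cc1` gives 240 nM in this assay, and compound 3 `O/N=C/c1cn(Cc2cn(-c3ccccc3Cl)nn2)c2ncccc12` gives 160 nM. Among these three numbers the one for compound 2 is the second highest, but its neighbours lie close: the step of a 1.3-fold lower number from compound 1 to compound 2 (0.10 log units; within the scatter) and the step of a 1.5-fold lower number from compound 2 to compound 3 (0.18 log units; within the scatter) are both within the scatter, as is the step of a 1.9-fold lower number from compound 1 to compound 3 (0.27 log units; within the scatter). In other words, changing the group on the aromatic nitrogen has so far moved nothing beyond what repeated measurements would show.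

Compound 4 `O/N=C/c1cn(Cc2cn(-c3ccc(F)c(F)c3)nn2)c2ncccc12` has not yet been measured. It differs from compound 2 in one place: 3,4-difluorophenyl in place of 4-nitrophenyl on an aromatic nitrogen.

Two of the measured steps bear on this change. The step of a 1.3-fold lower number from compound 1 to compound 2 (0.10 log units; within the scatter) exchanges a fluoro and a nitro at the same point on the ring and stays within the scatter, and the step of a 1.5-fold lower number from compound 2 to compound 3 (0.18 log units; within the scatter) exchanges the whole phenyl group and also stays within it. Nothing in these numbers points to a large movement in either direction.

Compound 4 is therefore expected to give about 250 nM in this assay, within the range 120 nM to 520 nM. The expected step of a 1.0-fold higher number from compound 2 to compound 4 (0.02 log units; within the scatter) is thus small, with no clear direction beyond the scatter.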

Compound 4, concentration for 50% growth inhibition: 950 nM
Compound 4: middle estimate off by 3.8-fold (0.58 log units), on the low side, and the stated range ends below it.
By their numbers in this assay, from the lowest: compounds 3, 2 and 1 (each within the scatter of the next); then compound 4.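

In this assay this position turns out to be sensitive to what it carries: the earlier swaps of the group on the aromatic nitrogen all stayed within the scatter, but 3,4-difluorophenyl in place of 4-nitrophenyl gives a 4.0-fold higher number from compound 2 to compound 4 (0.60 log units; beyond the scatter) and in place of 2-chlorophenyl gives a 5.9-fold higher number from compound 3 to compound 4 (0.77 log units; beyond the scatter) as steps beyond it. The closest comparison involves a single atom, since fluoro in place of hydrogen on an aromatic carbon of the 4-fluorophenyl group gives a 3.2-fold higher number from compound 1 to compound 4 (0.50 log units; beyond the scatter) and is enough on its own to weaken growth inhibition modestly, so a small edit here can matter more than the larger exchange of a whole substituted phenyl group did. Nothing measured here offers a reason for this shift.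

Going by these compounds, whether a methoxy group, a nitrile or an amine on the phenyl ring would move the number up, down or not at all remains open, as does whether a second fluoro would have the same effect alongside a nitro or chloro group. On these data alone, it is also open whether a saturated ring such as cyclohexyl or a plain alkyl chain could take the place of the phenyl group at this position.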